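The source may report more compounds than this note shows. Statements on the series, on what has been measured and on what is new or still open speak of the compounds shown alone.

In a functional assay on P388 cells (Mus musculus) for cytotoxicity (on this read-out higher numbers stand for weaker inhibition and lower numbers for stronger inhibition), compound 1 (`COc1ccc(C[C@H]2C(=O)N[C@@H](C)C(=O)N(C)[C@H]3Cc4ccc(cc4)Oc4cc(ccc4OC)C[C@@H](C(=O)N[C@H](C)C(=O)N[C@@H](CC(=O)O)C(=O)N2C)N(C)C3=O)cc1`) gives 1200 nM while compound 2 (`COc1ccc(C[C@H]2C(=O)N[C@@H](C)C(=O)N(C)[C@H]3Cc4ccc(cc4)Oc4cc(ccc4OC)C[C@@H](C(=O)N[C@H](C)C(=O)N[C@@H](CCO)C(=O)N2C)N(C)C3=O)cc1`) gives 60.3 nM and compound 3 (`CCCCN1C(=O)[C@@H](C)NC(=O)[C@@H]2Cc3ccc(OC)c(c3)Oc3ccc(cc3)C[C@@H](C(=O)N2C)N(C)C(=O)[C@H](C)NC(=O)[C@H](Cc2ccc(OC)cc2)N(C)C(=O)[C@@H]1C`) gives 12 nM as its result. Compound 3 therefore has the lowest number of the three, and its gaps to both others lie beyond the scatter. Compound 4 (`C=C(C)CN1C(=O)[C@@H](C)NC(=O)[C@@H]2Cc3ccc(OC)c(c3)Oc3ccc(cc3)C[C@@H](C(=O)N2C)N(C)C(=O)[C@H](C)NC(=O)[C@H](Cc2ccc(OC)cc2)N(C)C(=O)[C@@H]1C`) differs from compound 3 in one place, on a saturated chain carbon bound to an amide-type nitrogen in a ring, where 1-methylethenyl stands in place of propyl (1-methylethenyl in place of propyl on a saturated chain carbon bound to an amide-type nitrogen in a ring). Cut one bond further out, butyl gives way to 2-methylprop-2-en-1-yl.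

Within the data shown here, only one measured step is available for comparison, a 20-fold lower number from compound 1 to compound 2 (1.30 log units; beyond the scatter), which comes with hydroxymethyl in place of carboxy on a saturated chain carbon bound to a saturated ring carbon. That step is large, but it involves different groups at a different place, so it says little about this change. Among the measured compounds shown here, no measured compound shows what a change at the butyl group does. The estimate therefore starts from compound 3 at 12 nM and keeps a wide range. The expected result is a 1.3-fold higher number from compound 3 to compound 4 (0.10 log units; within the scatter) and this estimated size stays within the scatter. In this assay compound 4 is expected at 15 nM with 5 nM to 45 nM as the estimated range.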

Compound 4, half-maximal inhibitory concentration: 11 nM
Estimate against measurement, compound 4: 1.4-fold (0.13 log units) above, within the range that was stated.
By their numbers in this assay, from the lowest: compounds 4 and 3 (each within the scatter of the next); then compound 2; then compound 1.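

In this assay the change to 1-methylethenyl in place of propyl, on a saturated chain carbon bound to an amide-type nitrogen in a ring, comes with a 1.1-fold lower number from compound 3 to compound 4 (0.04 log units; within the scatter) and therefore cannot be told apart from no change on this read-out. Among these compounds, this is the first measured step at this place, and it shows that butyl and 2-methylprop-2-en-1-yl give matching results here, even though the entering group brings one double bond outside aromatic rings and the heavy-atom count of the changed group stays the same. The data shown offer no measurement that explains this match, so the result stands as an observation without an explanation.

Among the compounds shown here, this single pair covers only two closely related carbon groups, so it remains open whether the same match would hold for an amine, a carboxylic acid, a hydroxyl group or a chain longer than butyl at this place. Going by these compounds, it also remains open whether the match between these two groups would persist in other assays or on a different core.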